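The compounds below may be only part of what the source reports. "The series", "measured", "known", "first", "only" and "open" are said of these compounds alone.

Measured so far:
- compound 1, `Cc1coc2cc(OCC(=O)Nc3cccc(NC(=O)c4ccc(N(C)C)cc4)c3)ccc2c1=O`, in an assay on isolated protein for inhibition of Rho-associated protein kinase 2 (Homo sapiens), read by scintillation counting, radiometric assay and 33P incorporation, with a stated time of 40 min, in the presence of a further agent that is not named here (a lower number here means a stronger inhibitor, a higher number a weaker inhibitor), gives 2150 nM
- compound 2, `Cc1cc(C(=O)Nc2cccc(NC(=O)COc3ccc4c(=O)ccoc4c3)c2)ccc1C(F)(F)F`, in this assay gives 43 nM
- compound 3, `CN(C)c1ccc(C(=O)Nc2ccc(NC(=O)COc3ccc4c(=O)ccoc4c3)cc2)cc1`, in this assay gives 302 nM

All three compounds share the same core and differ in how the two amide-linked benzene rings are substituted. Compound 3 sits in the middle of the three numbers: its value in this assay is higher than that of compound 2 and lower than that of compound 1, and both of those gaps are larger than the usual scatter of repeated measurements.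

Compound 4, `CN(C)c1ccc(C(=O)Nc2ccc(NC(=O)COc3ccc4c(=O)ccoc4c3)cc2C(F)(F)F)cc1`, has not yet been measured. It keeps everything in compound 3 and makes one change: trifluoromethyl in place of hydrogen on an aromatic carbon. The new group sits on the central ring, on an aromatic carbon of a six-membered aromatic ring of carbon only, ortho to a ((4-(dimethylamino)phenyl)carbonyl)amino group and meta to a large group.

Among the measured compounds shown here, no pair among the measured compounds differs only in this place, so there is no directly comparable step to lean on. The expectation is therefore a cautious one: compound 4 is estimated to show a step of a 1.5-fold higher number from compound 3 to compound 4 (0.17 log units; within the scatter), a modest loss that may not exceed the scatter. On that basis compound 4 is expected to give about 450 nM in this assay, within a range from 110 nM to 1800 nM.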

Compound 4, half-maximal inhibitory concentration: 7100 nM
Compound 4: middle estimate off by 16-fold (1.20 log units), on the low side; measured number outside the range, above it.
By their numbers in this assay, from the lowest: compound 2; then compound 3; then compound 1; then compound 4.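

In this assay, putting trifluoromethyl on this aromatic carbon, ortho to a ((4-(dimethylamino)phenyl)carbonyl)amino group and meta to a large group, gives a 24-fold higher number from compound 3 to compound 4 (1.37 log units; beyond the scatter), a large loss of inhibition. Among the compounds shown here, the earlier compounds held no pair that differed only here, so this is the first sign that this carbon is far from indifferent to what it carries: a single swap of hydrogen for a group of four heavy atoms, with everything else kept, is enough to produce that loss. Nothing shown here measures why the change costs so much.

As far as these compounds go, it remains open whether the loss belongs to trifluoromethyl in particular or to any group on this carbon, a question that a single fluorine atom, a methyl group or a methoxy group at the same place could help to settle. From the compounds shown here alone, it is equally open whether other carbons of the same ring respond in the same way, and whether the step keeps its size when the dimethylamino group on the far ring is replaced by something else.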